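Metabolic stability from compound 2 to an ethyl analogue

The source may report more compounds than this note shows. Statements on the series, on what has been measured and on what is new or still open speak of the compounds shown alone.

This account follows one change to compound 2 `CC(C)n1cc(-c2ccnc3[nH]c(C4CCN(CC(=O)N(C)C)CC4)cc23)cnc1=O` and what it may do in an ADME assay on microsomes from liver (Homo sapiens) for metabolic stability; a higher number here means faster removal of the compound, a lower number slower removal. Within the data shown here, the compounds measured so far are compound 1 `CC(C)n1cc(-c2ccnc3[nH]c(C4CCN(CC(=O)N5CCCC5)CC4)cc23)ccc1=O` and compound 2. In this assay compound 1 gives 45 uL/min and compound 2 gives 24 uL/min; the two numbers fall within the usual scatter of each other, so neither can be called more stable than the other.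

The new member is compound 3 `CCn1cc(-c2ccnc3[nH]c(C4CCN(CC(=O)N(C)C)CC4)cc23)ccc1=O`. Compared with compound 2, it carries a group of 9 heavy atoms (7 carbon, 1 nitrogen, 1 oxygen; one six-membered aromatic ring with 1 hetero atom) in place of a group of 10 heavy atoms (7 carbon, 2 nitrogen, 1 oxygen; one six-membered aromatic ring with 2 hetero atoms), on an aromatic carbon. Among the measured compounds shown here, no step between measured compounds isolates this change, so there is no direct precedent to lean on. Compound 3 is expected to sit close to compound 2, with a step from compound 2 to compound 3 of a 1.3-fold higher number from compound 2 to compound 3 (0.10 log units; within the scatter), which stays inside the scatter. The estimate for compound 3 in this assay is 30 uL/min, with a range from 15 uL/min to 60 uL/min.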

Compound 3, intrinsic clearance in a liver preparation (reported as CLH), per the amount of preparation that the assay uses: < 3 uL/min
Compound 3 ended at the assay's limit (the forecaster's own chance of this, stated with the estimate: 5%); middle value at least 10-fold (1.00 log units) away from the limit.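

Among these compounds, at this place, on an aromatic carbon of a six-membered aromatic ring with 1 nitrogen, part of a fused or bridged system of two rings, the exchange of groups is the first single change that can be read in this assay, and it gives an at least 8.0-fold lower number from compound 2 to compound 3 (0.90 log units; beyond the scatter). Compound 1 and compound 2 differ in more than one place and could not show that the group here can move the number beyond the scatter. Compound 3 gives < 3 uL/min, which is a limit of the assay and not a number: the limit of < 3 uL/min in this assay, at which 1 of the 3 values shown sits.

The exchange alters the aromatic ring and the alkyl chain together, so the compounds shown cannot tell which part carries the step. On these data alone, whether a methyl or a cyclopropyl group in place of the ethyl group of compound 3 would keep the number this low also stays open.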